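Three limits and a chloro-to-ethoxy swap on the anilide

The source may report more compounds than this note shows. Statements on the series, on what has been measured and on what is new or still open speak of the compounds shown alone.

Compound 1, `COc1ccc2c(=O)c(/C=C/C(=O)Nc3cccc(C)c3)coc2c1`: in a functional assay on HeLa cells (Homo sapiens) for inhibition, read by MTT assay, with a stated time of 48 h (a higher number here means a weaker inhibitor, a lower number a stronger inhibitor), compound 1 gives only a limit, > 100000 nM.
Compound 2, `COc1ccc2c(=O)c(/C=C/C(=O)NCc3ccc(C)cc3)coc2c1`: in this assay compound 2 gives only a limit, > 100000 nM.
Compound 3, `COc1ccc2c(=O)c(/C=C/C(=O)Nc3ccc(Cl)cc3)coc2c1`: in this assay compound 3 gives only a limit, > 100000 nM.

On the numbers shown, compound 3 stands at a limit rather than at a number, and it shares that position with the two other compounds, all three sitting at the limit of > 100000 nM in this assay, at which 3 of the 3 values shown sit. The three steps among them are accordingly of unknown size: a step that the two limits leave unreadable from compound 1 to compound 2, a step that the two limits leave unreadable from compound 1 to compound 3 and a step that the two limits leave unreadable from compound 2 to compound 3. None of them tells whether exchanging the group on the amide-type nitrogen moves the potency at all.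

Compound 4, `CCOc1ccc(NC(=O)/C=C/c2coc3cc(OC)ccc3c2=O)cc1`, differs from compound 3 by ethoxy in place of chloro on an aromatic carbon. The change thus again alters only the substituent on the aryl group carried by the amide-type nitrogen, the same place where the three unreadable steps sit. With every comparable step hidden by the limit, no step beyond the scatter can be expected in this assay from compound 3 to compound 4, and compound 4 is estimated to fall at the limit as well, an expected step of a number no higher from compound 3 to compound 4 (the limit leaves the size open). Compound 4 is therefore estimated at 100000 nM in this assay, with an expected range from 30000 nM to 300000 nM.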

Compound 4, half-maximal inhibitory concentration: > 100000 nM
Compound 4 ended at the assay's limit; the forecaster's own chance of this, stated with the estimate: 80%; the middle value sits exactly at the limit.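

In this assay compound 4 gives only a limit, > 100000 nM. For the compounds shown here, no step between compound 4 and compound 1, compound 2 or compound 3 can be read, as all four compounds stand at the same limit: the limit of > 100000 nM in this assay, at which 4 of the 4 values shown sit. The compounds shown leave open whether any change to the group on the amide-type nitrogen moves the potency at all.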